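From carboxymethyl to 1-carboxycyclopropyl: an expected clearance

The source may hold more compounds than are shown below. What is called first, only, known or untested is meant among the compounds shown, and "the series" means these compounds.

- Compound 1 `CCOc1cc2[nH]c(Cc3nn(CC(=O)O)c(=O)c4ccccc34)nc2cc1Cl` gives < 15.2 mL/min/kg (a limit, not a number)
- Compound 2 `O=C(O)Cc1nn(Cc2cn3cc(OCC4CC4)c(Cl)cc3n2)c2ccccc2c1=O` gives 18.3 mL/min/kg (a measured number)

Among the compounds with values here, in an ADME assay on microsomes from liver (Homo sapiens) for metabolic stability (a higher number here means faster removal of the compound, a lower number slower removal), compound 2 gives 18.3 mL/min/kg as the only true number so far. Compound 1 offers no number to set against it, only a limit.

The next compound, compound 3 `O=C(O)C1(c2nn(Cc3cn4cc(OCC5CC5)c(Cl)cc4n3)c3ccccc3c2=O)CC1`, keeps the rest of compound 2 and carries 1-carboxycyclopropyl in place of carboxymethyl on an aromatic carbon. The group grows by a three-membered ring of carbon, while its acid function stays in the same spot on the core.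

Within the data shown here, no measured pair of compounds shows what a swap of this kind does, so the data give no direct guide to its size or direction. The plainest expectation is no change beyond the usual scatter in this assay, starting from compound 2 at 18.3 mL/min/kg as the sole anchor. The expected move is a 1.0-fold lower number from compound 2 to compound 3 (0.01 log units; within the scatter) and may be small. Compound 3 is expected to give about 18 mL/min/kg in this assay, with 15 mL/min/kg to 30 mL/min/kg as the estimated range.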

Compound 3, clearance: < 15 mL/min/kg
Compound 3 ended at the assay's limit; the forecaster's own chance of this, stated with the estimate: 30%; at least 1.2-fold (0.07 log units) between middle value and limit.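

In this assay compound 3 gives < 15 mL/min/kg, which is a limit of the assay and not a number. Putting 1-carboxycyclopropyl in place of carboxymethyl, on the aromatic carbon next to the ring nitrogen, gives an at least 1.2-fold lower number from compound 2 to compound 3 (0.08 log units; that floor lies within the scatter). This is the first measured step at this position, and it shows that adding the three-membered ring of carbon to the group that carries the acid comes with no rise in the number, although the step is only a floor and its true size stays hidden: the limit of < 15 mL/min/kg in this assay, at which 1 of the 3 values shown sits.

Going by these compounds, what remains open is how far the true number of compound 3 lies under its limit, so whether this swap matters beyond the usual scatter cannot be told. Also open, on these data alone, is how this position would respond to other groups, such as 1-carboxycyclobutyl with its four-membered ring of carbon, a longer chain ending in a carboxylic acid, or an amide in place of the acid, and whether the same swap would act alike on the core of compound 1.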